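A few compounds are considered here, and "the series" means these few. Any claim that something is new, unique, unknown or untested is made for them only; others in the source may bear on it.

Measured in an ADME assay on brain (Rattus norvegicus) for protein binding; on this read-out higher numbers stand for a larger free fraction and lower numbers for a smaller free fraction:
- Compound 1 `Cc1cccc(-c2ccc(NC[C@H]3CC[C@]4(CC3)CN(c3cccnn3)C(=O)O4)nc2)n1`: 0.056
- Compound 2 `O=C1O[C@]2(CC[C@H](CNc3cnn(-c4ccccc4F)c3)CC2)CN1c1cncnc1`: 0.044
- Compound 3 `O=C1O[C@]2(CC[C@H](CNc3ccc(C(F)(F)F)cn3)CC2)CN1c1ccccn1`: 0.005

Compound 2, at 0.044, lies within the scatter of compound 1 and well beyond the scatter above compound 3. Compound 4 `O=C1O[C@]2(CC[C@H](CNc3cnn(-c4ccccc4F)c3)CC2)CN1c1cccnc1F` has 2-fluoropyridin-3-yl in place of pyrimidin-5-yl on an amide-type nitrogen in a ring. For the measured compounds named here, no two measured compounds differ in one place only, so this expectation is a judgement. Compound 3, at 0.005, shows how low values can fall among these compounds. A small downward step, just past the scatter, is expected, estimated as a 2.2-fold lower number from compound 2 to compound 4 (0.34 log units; beyond the scatter). For compound 4 the estimated value is 0.02, with an expected range of 0.008 to 0.045.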

Compound 4, unbound fraction: 0.019
Beside the measured number, compound 4's estimate is 1.1-fold (0.02 log units) above it; the range from low to high includes it.
By their numbers in this assay, from the lowest: compound 3; then compound 4; then compounds 2 and 1 (each within the scatter of the next).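

In this assay, for the compounds shown here, this is the first comparison in which only one group changes: 2-fluoropyridin-3-yl in place of pyrimidin-5-yl on the amide-type nitrogen gives a 2.3-fold lower number from compound 2 to compound 4 (0.36 log units; beyond the scatter). The group at this position can therefore shift the free fraction beyond the scatter while the rest of the molecule stays fixed, though the step is modest. Nothing available explains the shift.

The compounds shown leave open whether the fluorine or the change in ring nitrogens matters more, a question that an unsubstituted pyridin-3-yl at this position would help to separate. As far as these compounds go, whether the same swap gives a similar step with a different group on the other end of the molecule also remains open.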